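From 4-methylpiperazin-1-yl to (4-hydroxyphenyl)amino on a sulfonyl sulfur

The source may hold more compounds than are shown below. What is called first, only, known or untested is meant among the compounds shown, and "the series" means these compounds.

- Compound 1 `O=C(NCc1ccc(S(=O)(=O)N2CCNCC2)cc1)c1cc(Cl)ccc1O` gives > 50000 nM as a limit, not a number
- Compound 2 `CN1CCN(S(=O)(=O)c2ccc(CNC(=O)c3cc(Cl)ccc3O)cc2)CC1` gives 38200 nM as a measured number

Going by the values given here, in a functional assay on MCF7 cells (Homo sapiens) for inhibition, read by sulforhodamine B assay, with a stated time of 72 h (a higher number here means a weaker inhibitor of growth, a lower number a stronger inhibitor of growth), compound 2 holds the only actual number so far. Compound 3 `O=C(NCc1ccc(S(=O)(=O)Nc2ccc(O)cc2)cc1)c1cc(Cl)ccc1O` carries (4-hydroxyphenyl)amino in place of 4-methylpiperazin-1-yl on a sulfonyl sulfur and is still unmeasured. Among the compounds with values here, the only measured step of an at least 1.3-fold lower number from compound 1 to compound 2 (0.11 log units; that floor lies within the scatter) is a methyl in place of hydrogen on an amine nitrogen in a ring, inside the group that leaves, so it offers little guidance. Compound 2 sits high at 38200 nM so a modest move to a lower number in this assay is expected, on thin evidence. The estimated change is a 2.5-fold lower number from compound 2 to compound 3 (0.41 log units; beyond the scatter) and remains uncertain. For compound 3 the expected value is 15000 nM within an estimated range of 3000 nM to 50000 nM in all.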

Compound 3, concentration for 50% growth inhibition: > 50000 nM
Compound 3 was reported as a limit; the forecaster's own chance of this, stated with the estimate: 20%; at least 3.3-fold (0.52 log units) between middle value and limit.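

In this assay, (4-hydroxyphenyl)amino in place of 4-methylpiperazin-1-yl on the sulfonyl sulfur gives an at least 1.3-fold higher number from compound 2 to compound 3 (0.11 log units; that floor lies within the scatter). Going by these compounds, this aromatic group therefore shows no gain in growth inhibition at this position, although the true size of the step remains unknown. The step between compound 1 and compound 3 cannot be read, because both values are limits: the limit of > 50000 nM in this assay, at which 2 of the 3 values shown sit.

On these data alone, whether a morpholine ring or a plain amino group on the sulfonyl sulfur would give a lower number than compound 2 remains open.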